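The compounds below may be only part of what the source reports. "The series", "measured", "known", "first", "only" and "open" are said of these compounds alone.

Working notes, measured in an ADME assay on the whole organism (Rattus norvegicus, strain Sprague-Dawley) for pharmacokinetics, read by LC-MS, with a stated time of 30 min, at a dose of 1 mg/kg by the intravenous route; a lower number here means slower removal, a higher number faster removal of the compound:

- compound 1 `N#Cc1ccc(S(=O)(=O)[C@H]2CN(S(=O)(=O)c3ccc(Cl)cc3Cl)C[C@@]2(O)CO)cc1` gives 25 mL/min/kg here
- compound 2 `N#Cc1ccc(S(=O)(=O)[C@H]2CN(S(=O)(=O)c3ccc(C#N)cc3Cl)C[C@@]2(O)CO)cc1` gives 35 mL/min/kg here

With only these two numbers, compound 2 and compound 1 lie within the scatter of each other, so the series does not yet separate on clearance.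

The next compound is compound 3 `N#Cc1ccc(S(=O)(=O)N2C[C@H](S(=O)(=O)c3ccc(Cl)cc3)[C@](O)(CO)C2)c(Cl)c1`, reached from compound 2 by a single exchange: chloro in place of cyano on an aromatic carbon (4-cyanophenyl to 4-chlorophenyl, chloro in place of cyano on an aromatic carbon, para to a large group).

Within the data shown here, one measured step bears on this, and only indirectly. The step of a 1.4-fold higher number from compound 1 to compound 2 (0.15 log units; within the scatter) swaps the same two groups in the opposite sense, at a different aromatic carbon. Read in reverse, it suggests at most a small shift towards a lower number, and a single step at another site is thin support.

No step beyond the scatter is therefore expected in this assay for this exchange. The expected change is a 1.3-fold lower number from compound 2 to compound 3 (0.10 log units; within the scatter) and nothing larger is predicted.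

For compound 3 the estimated clearance is 28 mL/min/kg (expected range 14 mL/min/kg to 55 mL/min/kg) on present evidence.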

Compound 3, clearance: 49 mL/min/kg
Estimate against measurement, compound 3: 1.8-fold (0.24 log units) below, within the range that was stated.
By their numbers in this assay, from the lowest: compounds 1, 2 and 3 (each within the scatter of the next).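

In this assay, chloro in place of cyano at this position, on an aromatic carbon para to a large group, gives a 1.4-fold higher number from compound 2 to compound 3 (0.15 log units; within the scatter), so the 4-cyanophenyl to 4-chlorophenyl exchange does not separate compound 2 and compound 3 on clearance. The earlier exchange, cyano in place of chloro at a different aromatic carbon, gave a 1.4-fold higher number from compound 1 to compound 2 (0.15 log units; within the scatter), so in these two single steps, the only ones available, swapping these two groups stays within the scatter at either site, and this position shows no clearer response to the exchange than the other site did. No measurement at hand offers an explanation for either step.

Both steps involve only cyano and chloro, so they leave open whether a group of a different kind, such as an amine or a carboxylic acid, on this aromatic carbon would give a step beyond the scatter in this assay. On these data alone, the shared core also remains untested here, so it is open whether a change away from these aromatic positions would move clearance further than either exchange has.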